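Triazole to difluoroethyl on the N-aryl ring

The source may hold more compounds than are shown below. What is called first, only, known or untested is meant among the compounds shown, and "the series" means these compounds.

Measured in a functional assay on HOS-TE85 cells (Homo sapiens) for inhibition, read by CCK-8 assay, with a stated time of 72 h; on this read-out lower numbers stand for stronger inhibition and higher numbers for weaker inhibition:
- compound 1 `O=C(NCCCCc1ccccc1)c1cccc(C2SCC(=O)N2c2cccc(-c3c[nH]nn3)c2)c1`: 110 nM
- compound 2 `COc1ccccc1N1C(=O)CSC1C(=O)NCCCCc1ccccc1`: > 1000 nM, a limit of this assay rather than a number

Compound 1 carries the only numerical value in this assay shown here. The other entry, for compound 2, is the limit of > 1000 nM in this assay, at which 1 of the 2 values shown sits, and says nothing about size beyond that.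

Compound 3 `CC(F)(F)c1cccc(N2C(=O)CSC2c2cccc(C(=O)NCCCCc3ccccc3)c2)c1` differs from compound 1 in one place: 1,1-difluoroethyl in place of 1H-1,2,3-triazol-4-yl on an aromatic carbon. Among the compounds with values here, no measured pair shows this change, so no measured step guides it. The leaving group brings one hydrogen-bond donor and two acceptors and a five-membered aromatic ring with three hetero atoms; the entering group has none of these. A step toward weaker inhibition in this assay, somewhat beyond the usual scatter, is expected, though a result within scatter is not excluded. Compound 3 is expected at 350 nM, within 90 nM to 1500 nM. That corresponds to an estimated step of a 3.2-fold higher number from compound 1 to compound 3 (0.50 log units; beyond the scatter).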

Compound 3, half-maximal inhibitory concentration in the HOS-TE85 assay: 29.1 nM
Compound 3: the middle estimate sits 12-fold (1.08 log units) above what was measured; measured number below the stated range.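

In the HOS-TE85 assay, 1,1-difluoroethyl in place of 1H-1,2,3-triazol-4-yl on this aromatic carbon gives a 3.8-fold lower number from compound 1 to compound 3 (0.58 log units; beyond the scatter), so inhibition at this position does not depend on the five-membered aromatic ring or on the hydrogen-bond donor and acceptors of the leaving group. In a physicochemical assay for solubility, read by turbidimetry, measured as kinetic solubility, at pH 6.8 (on this read-out higher numbers stand for higher solubility and lower numbers for lower solubility), compound 1 gives 20000 nM and compound 3 gives 10000 nM, two values within the usual scatter of each other. Nothing measured here bears on what lies behind the step in inhibition.

An ethyl, a trifluoromethyl or a carboxylic acid on the same aromatic carbon would show whether the fluorines matter or whether removing the triazole alone accounts for the step. On these data alone, whether the step holds with a shorter chain on the amide remains open.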